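Shrinking the Ring on the Amide Carbonyl

The compounds below may be only part of what the source reports. "The series", "measured", "known", "first", "only" and "open" are said of these compounds alone.

Three compounds share one core and differ only in the group on a carbonyl carbon. Compound 1 `COc1ccc(-c2cn3cc(C4=CCN(C(=O)c5ccccc5C(F)(F)F)CC4)ccc3n2)cc1OC` gives 8110 nM in a functional assay on B16-F10 cells (Mus musculus) for antiproliferative activity, read by MTT assay, with a stated time of 48 h; on this read-out higher numbers stand for weaker inhibition and lower numbers for stronger inhibition. Compound 2 `COc1ccc(-c2cn3cc(C4=CCN(C(=O)c5cccs5)CC4)ccc3n2)cc1OC` gives 19500 nM in this assay, which is a 2.4-fold higher number from compound 1 to compound 2 (0.38 log units; beyond the scatter). Compound 3 `COc1ccc(-c2cn3cc(C4=CCN(C(=O)C5CCCCC5)CC4)ccc3n2)cc1OC` gives 10900 nM in this assay; this is the second highest of the three numbers, with a 1.3-fold higher number from compound 1 to compound 3 (0.13 log units; within the scatter) and a 1.8-fold lower number from compound 2 to compound 3 (0.25 log units; within the scatter), so compound 3 cannot be ranked against either neighbour.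

Compound 4 `COc1ccc(-c2cn3cc(C4=CCN(C(=O)C5CC5)CC4)ccc3n2)cc1OC` has not yet been measured. It differs from compound 3 by cyclopropyl in place of cyclohexyl on a carbonyl carbon. Among the measured compounds shown here, no measured step alters the size of a saturated ring on this carbonyl carbon; the steps that do touch this position, reaching compound 3 from compound 1 and from compound 2, both stayed within the scatter, which suggests the position tolerates change without large effects on the read-out. Compound 4 is therefore expected to move little, a 1.1-fold higher number from compound 3 to compound 4 (0.04 log units; within the scatter), and its value in this assay is estimated at 12000 nM, within a range from 5000 nM to 30000 nM.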

Compound 4, half-maximal inhibitory concentration: 19400 nM
Estimate against measurement, compound 4: 1.6-fold (0.21 log units) below, and the stated range covers the measured number.
By their numbers in this assay, from the lowest: compounds 1, 3, 4 and 2 (each within the scatter of the next, the first and the last beyond it).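

Among the compounds shown here, changing the ring size on this carbonyl carbon for the first time, from cyclohexyl to cyclopropyl, gives in this assay a 1.8-fold higher number from compound 3 to compound 4 (0.25 log units; within the scatter), so this change does not separate the two compounds. Cyclopropyl also cannot be told apart from thiophen-2-yl, with a 1.0-fold lower number from compound 2 to compound 4 (0.00 log units; within the scatter), yet its exchange for 2-(trifluoromethyl)phenyl gives a 2.4-fold higher number from compound 1 to compound 4 (0.38 log units; beyond the scatter), which makes compound 4 the second compound beyond the scatter from compound 1, by a modest step. No measurement available here explains these numbers.

The compounds shown leave open whether a cyclopentyl ring would fit the same picture, or whether ring size matters here at all. They also leave open how a group carrying an amine or a carboxylic acid on this carbonyl carbon would read in this assay.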